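Naphthyl Regioisomer Swap on the Pyrazoline-Type Core

This account rests on a few compounds, and the source may have more. Where it says the series, first, only, none or still open, it means among the compounds named here.

For the measured compounds named here, two analogues of this series have numbers so far. Compound 1 `Fc1ccc(C2=NN(C3=NC(c4ccccc4)CS3)C(c3cccc4ccccc34)C2)cc1` carries a fluorophenyl group and a naphthalen-1-yl group; in a functional assay on BGC-823 cells (Homo sapiens) for inhibition, read by CCK-8 assay, with a stated time of 48 h (a lower number here means a stronger inhibitor, a higher number a weaker inhibitor), compound 1 gives 22700 nM. Compound 2 `Cc1ccc(C2=NN(C3=NC(c4ccccc4)CS3)C(c3ccc4ccccc4c3)C2)cc1C` carries a 3,4-dimethylphenyl group and a naphthalen-2-yl group; in this assay compound 2 gives 6570 nM. Compound 2 has the lowest of the two numbers, and compound 1 the higher one, the gap lying beyond the usual scatter. The two compounds differ in two places, so nothing can be read from the pair about either change alone.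

Compound 3 `Cc1ccc(C2=NN(C3=NC(c4ccccc4)CS3)C(c3cccc4ccccc34)C2)cc1C` keeps the 3,4-dimethylphenyl group of compound 2 and differs from compound 2 only as follows: naphthalen-1-yl in place of naphthalen-2-yl on a saturated ring carbon. Compound 3 shares its naphthalen-1-yl group with compound 1, whose number of 22700 nM is the weaker one seen, while its 3,4-dimethylphenyl group is that of compound 2. Going by the values given here, no single-point step is available to size the change. The expectation is a modest loss in this assay relative to compound 2, with the step from compound 2 to compound 3 estimated at a 1.7-fold higher number from compound 2 to compound 3 (0.22 log units; within the scatter), though a step within the scatter cannot be ruled out. Compound 3 is therefore expected to give about 11000 nM, within a range of 3500 nM to 35000 nM.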

Compound 3, half-maximal inhibitory concentration: 8460 nM
Beside the measured number, compound 3's estimate is 1.3-fold (0.11 log units) above it, within the range that was stated.
By their numbers in this assay, from the lowest: compounds 2 and 3 (each within the scatter of the next); then compound 1.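

In this assay, moving the attachment of the naphthalene on the saturated ring carbon, naphthalen-1-yl in place of naphthalen-2-yl with the 3,4-dimethylphenyl group held constant, gives a 1.3-fold higher number from compound 2 to compound 3 (0.11 log units; within the scatter), so at this position the two regioisomers cannot be told apart in this pair. For the compounds shown here, the change at the other site, 3,4-dimethylphenyl in place of 4-fluorophenyl on a carbon with a double bond to nitrogen with naphthalen-1-yl held constant, gives a 2.7-fold lower number from compound 1 to compound 3 (0.43 log units; beyond the scatter), which makes it the only single-place step so far that lies beyond the scatter. Nothing available explains the size of either step.

Naphthalen-2-yl appears here only with the 3,4-dimethylphenyl group, so it remains open whether the two regioisomers would also match with 4-fluorophenyl at the other site. Also open, as far as these compounds go, is how the saturated ring carbon responds to anything other than a naphthyl group, such as a pyridine ring, a phenyl ring bearing a carboxylic acid, or one bearing a dimethylamino group.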